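A few compounds are considered here, and "the series" means these few. Any claim that something is new, unique, unknown or untested is made for them only; others in the source may bear on it.

In an ADME assay on THP-1 cells (Homo sapiens) for cytotoxicity, read by MTT assay, tested at 50 ug/mL (a higher number here means more inhibition at the concentration tested (going by the name of the read-out), a lower number less inhibition), compound 2 `COc1ccc(-c2csc(N/N=C/c3ccc(-n4ccnc4)cc3)n2)cc1` gives 26.8%. Compound 1 `C(=N/Nc1nc(-c2ccccc2)cs1)\c1ccc(-n2ccnc2)cc1` gives 21.8% in this assay, so the two sit side by side within the scatter of one another. For the measured compounds named here, the single measured step, a number 5 percentage points higher from compound 1 to compound 2 (within the scatter), is the only guide. Compound 3 `O=[N+]([O-])c1ccc(-c2csc(N/N=C/c3ccc(-n4ccnc4)cc3)n2)cc1` differs from compound 2 by nitro in place of methoxy on an aromatic carbon. Going by the values given here, no measured step exchanges these two groups, and the one step that touches this position stayed within the scatter, so compound 3 is expected to shift by about a number 0.2 percentage points higher from compound 2 to compound 3 (within the scatter), nothing beyond the scatter. Compound 3 is therefore estimated at 27%, between 12% and 42%.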

Compound 3, a percentage reported as inhibition, at one concentration (the size of the read-out at that concentration, not a potency): 16.4%
The estimate for compound 3 lay 10.6 percentage points above the measured number; measured number inside the range.
By their numbers in this assay, from the lowest: compounds 3, 1 and 2 (each within the scatter of the next, the first and the last beyond it).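

In this assay, for the compounds shown here, the change from 4-methoxyphenyl to 4-nitrophenyl gives the first step at this position beyond the scatter, a number 10.4 percentage points lower from compound 2 to compound 3 (beyond the scatter). Against hydrogen, nitro stays within the scatter, a number 5.4 percentage points lower from compound 1 to compound 3 (within the scatter), so the position separates methoxy from nitro, while neither group stands clear of hydrogen. Nothing measured here accounts for that gap. As far as these compounds go, whether an amine or a carboxylic acid on the same aromatic carbon would stand clear of hydrogen remains open, as does whether a longer alkoxy chain would stay with methoxy.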